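Swapping the Amide Amine in a Cytotoxicity Series

A few compounds are considered here, and "the series" means these few. Any claim that something is new, unique, unknown or untested is made for them only; others in the source may bear on it.

Measured compounds:
Compound 1, `COc1ccc(OC)c(-c2cc(-c3ccc(C(=O)N4CCCCC4)s3)on2)c1`, in a functional assay on PC-3 cells (Homo sapiens) for cytotoxicity, read by XTT assay, with a stated time of 72 h (on this read-out higher numbers stand for weaker inhibition and lower numbers for stronger inhibition), gives > 30000 nM, which is a limit of the assay and not a number.
Compound 2, `CCN(CC)C(=O)c1ccc(-c2cc(C3=CC(=O)C=CC3=O)no2)s1`, in this assay gives 8900 nM.
Compound 3, `CCN(CC)C(=O)c1ccc(-c2cc(-c3cc(OC)ccc3OC)no2)s1`, in this assay gives > 30000 nM, again a limit of the assay rather than a number.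

Among the measured compounds shown here, compound 2 therefore holds the only actual number in this set; the other two values are limits. For the measured compounds named here, the one measured step that alters the amine on the carbonyl carbon is a step that the two limits leave unreadable from compound 1 to compound 3, and because both of its ends sit at the limit of > 30000 nM in this assay, at which 2 of the 3 values shown sit, its size cannot be read. Compound 4, `O=C1C=CC(=O)C(c2cc(-c3ccc(C(=O)N4CCCC4)s3)on2)=C1`, is not yet measured. It differs from compound 2 by pyrrolidin-1-yl in place of diethylamino on a carbonyl carbon. Going by the values given here, no measured step gives a readable size for such a change, so no direction can be drawn from the data, and the step of no change at the digits printed from compound 2 to compound 4 (within the scatter) is expected to stay within the usual scatter. Compound 4 is accordingly estimated to give about 8900 nM in this assay, with a range from 3000 nM to 27000 nM.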

Compound 4, half-maximal inhibitory concentration: < 30000 nM
Compound 4 ended at the assay's limit; the forecaster's own chance of this, stated with the estimate: 15%; the middle value does not contradict the limit.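

Compound 4 gives < 30000 nM in this assay, which is a limit of the assay and not a number. No size can be read for the step between compound 2 and compound 4. The compounds shown leave open whether pyrrolidin-1-yl in place of diethylamino on a carbonyl carbon shifts the read-out at all.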